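A Hydroxyl Swap on the Butyl Chain of Compound 1

The source may hold more compounds than are shown below. What is called first, only, known or untested is meant among the compounds shown, and "the series" means these compounds.

Among the measured compounds shown here, compound 1 `CCCCc1cnc(C(CCCC)Cc2ccc(-c3ccccc3C(=O)O)cc2)[nH]1` is one of two compounds measured in an in vitro functional assay on cells for agonist activity at Bombesin receptor subtype-3 (Homo sapiens), read by luminescence and calcium flux; on this read-out higher numbers stand for an effect only at larger amounts of compound and lower numbers for an effect already at smaller amounts. In this assay compound 1 gives 2660 nM, the higher of the two numbers shown. The other, compound 2 `O=C(O)c1ccccc1-c1ccc(CCc2ncc(Cc3ccccc3Cl)[nH]2)cc1`, gives 292 nM in this assay; the two structures differ in more than one place, so these two values stand side by side without a single change to tie them together.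

Compound 3 `CCCCc1cnc(C(CCCO)Cc2ccc(-c3ccccc3C(=O)O)cc2)[nH]1` has not yet been measured. It differs from compound 1 in one place: hydroxy in place of methyl on a saturated chain carbon, four bonds along the chain from an aromatic carbon. Hydroxy in place of methyl on a saturated chain carbon, four bonds along the chain from an aromatic carbon, turns the butyl chain into a 3-hydroxypropyl chain. For the measured compounds named here, no measured pair shows this change, so its effect in this assay is open. The expected step is a 1.3-fold lower number from compound 1 to compound 3 (0.12 log units; within the scatter), modest in size and possibly none beyond the scatter. Compound 3 is therefore estimated at 2000 nM in this assay, with a range from 600 nM to 6500 nM.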

Compound 3, half-maximal effective concentration: 1900 nM
Beside the measured number, compound 3's estimate is 1.1-fold (0.02 log units) above it; the range from low to high includes it.
By their numbers in this assay, from the lowest: compound 2; then compounds 3 and 1 (each within the scatter of the next).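

Hydroxy in place of methyl, which turns the butyl chain into a 3-hydroxypropyl chain, gives a 1.4-fold lower number from compound 1 to compound 3 (0.15 log units; within the scatter) in this assay. Among the compounds shown here, this is the first single change that can be read, since compounds 1 and 2 differ in more than one place, and it shows that this position can take one hydrogen-bond donor and one hydrogen-bond acceptor, neither of which the methyl has, without a shift in the number beyond the usual scatter of repeated measurements. Nothing available here explains why the two numbers stay so close, and this single pair cannot show whether the hydroxy has any real effect of its own in this assay.

The compounds shown leave open whether this position would respond differently to an amine, a carboxylic acid or a longer chain ending in hydroxy. They also leave open whether the same swap on the second butyl chain of compound 1 would stay within the scatter, and whether the change would behave alike on the core of compound 2.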